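The source may hold more compounds than are shown below. What is called first, only, known or untested is meant among the compounds shown, and "the series" means these compounds.

Compound 1 `COc1ccc(CNc2nc3cc(N)cc(N)c3nc2-c2ccccc2)cc1OC` gives 60300 nM in a functional assay on SF-268 cells (Homo sapiens) for inhibition, read by sulforhodamine B assay, with a stated time of 48 h; a higher number here means a weaker inhibitor of growth, a lower number a stronger inhibitor of growth.
Compound 2 `COc1ccc(CNc2nc3cc(N)cc(N)c3nc2-c2ccccc2)cc1` gives 21900 nM in this assay.
Compound 3 `COc1ccc(Sc2nc3cc(N)cc(N)c3nc2-c2ccccc2)cc1` is reported in this assay only as < 100000 nM, a limit of the assay and not a number.

The three share one core, a flat two-ring system carrying two amino groups and a phenyl group, and differ in the side group attached through a linker. Between compound 1 and compound 2 the linker is the same and only one methoxy is removed; the step of a 2.8-fold lower number from compound 1 to compound 2 (0.44 log units; beyond the scatter) shows that this trimming made the compound a modestly stronger inhibitor of growth. Compound 3 swaps the nitrogen linker for sulfur, and for it the assay yields only a limit; on that point the limit of < 100000 nM in this assay, at which 1 of the 3 values shown sits, is all that is known, so where compound 3 stands relative to the other two cannot be said.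

Compound 4 `Nc1cc(N)c2nc(-c3ccccc3)c(Sc3ccc(F)cc3)nc2c1` is the next member of the sulfur-linked pair: fluoro in place of methoxy on an aromatic carbon. For the measured compounds named here, no measured step replaces a methoxy with a fluoro, and the only step that exists, from compound 1 to compound 2, concerns the nitrogen-linked compounds. With compound 3 known only as a limit, the change from compound 3 to compound 4 is expected to be small, within or near the scatter, so a step that the limit leaves unreadable from compound 3 to compound 4 is an estimate with little support. Compound 4 is therefore expected to give about 70000 nM in this assay, with a range from 15000 nM to 100000 nM.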

Compound 4, concentration for total growth inhibition: 38900 nM
Compound 4: middle estimate off by 1.8-fold (0.26 log units), on the high side; the range from low to high includes it.
By their numbers in this assay, from the lowest: compounds 2, 4 and 1 (each within the scatter of the next, the first and the last beyond it).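

The change of methoxy to fluoro between compound 3 and compound 4 gives no step that can be read, because compound 3 is known only as a limit of the assay, not a number: the limit of < 100000 nM in this assay, at which 1 of the 4 values shown sits.

The compounds shown leave open how much this swap of methoxy for fluoro shifts the number in this assay.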